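The source may report more compounds than this note shows. Statements on the series, on what has been measured and on what is new or still open speak of the compounds shown alone.

Compound 3 `Cc1cc(C(=O)Nc2ccc(Cl)cc2)ccc1N(CC(=O)N1CCOCC1)C(=O)Nc1ccc(Cl)cc1` gives the highest number of the three measured compounds in an ADME assay on microsomes from liver (Rattus norvegicus) for metabolic stability (on this read-out lower numbers stand for a shorter-lived compound and higher numbers for a longer-lived compound), namely 0.765 h. Compound 1 `Cc1cc(C(=O)Nc2ccc(F)cn2)ccc1N(CCN1CCCC1)C(=O)Nc1ccc(Cl)cc1` gives 0.267 h in this assay, and compound 2 `Cc1cc(C(=O)Nc2ccc(Cl)cc2)ccc1N(CCN1CCCC1=O)C(=O)Nc1ccc(Cl)cc1` gives 0.075 h; both lie beyond the scatter below compound 3. Within the data shown here, the one measured step that changes a single place is a 10-fold higher number from compound 2 to compound 3 (1.01 log units; beyond the scatter), a large rise.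

Compound 4 `Cc1cc(C(=O)Nc2ccc(Cl)cc2)ccc1N(CCN1CCCC1)C(=O)Nc1ccc(Cl)cc1` differs from compound 3 by (pyrrolidin-1-yl)methyl in place of (morpholin-4-yl)carbonyl on a saturated chain carbon bound to an amide-type nitrogen. Among the measured compounds shown here, no measured step carries exactly this change. The step from compound 2 to compound 3 concerns the same position, and it showed that the chain end on this saturated carbon can move the half-life strongly. Compound 1 carries the same 2-(pyrrolidin-1-yl)ethyl chain as compound 4, and in this assay compound 1 gives 0.267 h, but it differs from compound 4 elsewhere as well, so its two values with compound 3 are only a hint.

On this basis a downward step is expected, a 3.5-fold lower number from compound 3 to compound 4 (0.54 log units; beyond the scatter), in this assay. Compound 4 is accordingly estimated at 0.22 h, within a range from 0.07 h to 0.65 h, because compound 1 with the same chain gives 0.267 h.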

Compound 4, half-life: 0.455 h
Compound 4: the middle estimate sits 2.1-fold (0.32 log units) below what was measured, and the stated range covers the measured number.
By their numbers in this assay, from the lowest: compound 2; then compounds 1, 4 and 3 (each within the scatter of the next, the first and the last beyond it).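

In this assay, (pyrrolidin-1-yl)methyl in place of (morpholin-4-yl)carbonyl on a saturated chain carbon bound to an amide-type nitrogen gives a 1.7-fold lower number from compound 3 to compound 4 (0.23 log units; within the scatter), so these two chain ends cannot be told apart on this read-out. The large rise seen earlier therefore does not need the (morpholin-4-yl)carbonyl group: pyrrolidin-1-yl in place of 2-oxopyrrolidin-1-yl gives a 6.1-fold higher number from compound 2 to compound 4 (0.78 log units; beyond the scatter), and among the three chain ends compared on the same core, 2-oxopyrrolidin-1-yl is the one that stands apart. With the 2-(pyrrolidin-1-yl)ethyl chain held constant, 4-chlorophenyl in place of 5-fluoropyridin-2-yl on an amide-type nitrogen gives a 1.7-fold higher number from compound 1 to compound 4 (0.23 log units; within the scatter), so this second place also shows no change that can be told from the scatter.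

Nothing at hand explains why the 2-oxopyrrolidin-1-yl chain end stands apart. As far as these compounds go, it remains open whether a piperidin-1-yl or dimethylamino chain end would stay with compounds 3 and 4 or lie nearer compound 2, and whether 5-fluoropyridin-2-yl would give as small a step with a chain end other than 2-(pyrrolidin-1-yl)ethyl.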